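The source may report more compounds than this note shows. Statements on the series, on what has been measured and on what is new or still open speak of the compounds shown alone.

In a toxicity assay on HepG2 cells (Homo sapiens) for inhibition, read by resazurin assay, with a stated time of 24 h (a higher number here means that more compound is tolerated, a lower number that less compound is tolerated), compound 1 `CN(C)C(=O)c1ncc([N+](=O)[O-])[nH]1` gives only a limit, > 100000 nM. Compound 2 `NC(=O)c1nc([N+](=O)[O-])cn1Cc1ccc(F)cc1` likewise gives only a limit, > 100000 nM. Compound 3 `NC(=O)c1nc([N+](=O)[O-])cn1Cc1ccc(OC(F)(F)F)cc1` also stands at a limit, > 100000 nM, so no number is known for it. Taken together, the record shows (the limit of > 100000 nM in this assay, at which 3 of the 3 values shown sit).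

Compound 4 `NNC(=O)c1nc([N+](=O)[O-])cn1Cc1ccc(OC(F)(F)F)cc1` differs from compound 3 by amino in place of hydrogen on an amide-type nitrogen, which turns carbamoyl into aminocarbamoyl. Within the data shown here, the one measured step available is a step that the two limits leave unreadable from compound 2 to compound 3, and it lies elsewhere in the structure and offers no size to carry over. No step beyond the scatter is therefore expected in either direction, and the estimated step is a number no higher from compound 3 to compound 4 (the limit leaves the size open). Compound 4 is expected at 100000 nM, with an estimated range of 40000 nM to 150000 nM.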

Compound 4, half-maximal cytotoxic concentration: > 100000 nM
Compound 4: no number, only a limit (the forecaster's own chance of this, stated with the estimate: 75%); the middle value sits exactly at the limit.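

Among these compounds, compound 3 and compound 4 both stand only at a limit in this assay, so no step between them can be read. The compounds shown leave open the actual half-maximal cytotoxic concentration of each, as the record holds no number: the limit of > 100000 nM in this assay, at which 4 of the 4 values shown sit.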